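This account rests on a few compounds, and the source may have more. Where it says the series, first, only, none or still open, it means among the compounds named here.

Two members of the series carry numbers in a functional assay (aorta) with Rattus norvegicus as the target; on this read-out lower numbers stand for lower potency and higher numbers for higher potency (the scale is a negative logarithm). Compound 1 `Cc1ccc(C)n1-c1ccc2c(c1)C(n1ccccc1=O)=CC(C)(C)O2` gives 7.27. Compound 2 `CC1(C)C=C(n2ccccc2=O)c2cc(OC(=O)Nc3ccccc3)ccc2O1` gives 5.3, the lower of the two values, and the gap to compound 1 lies well beyond the scatter. Compound 3 `CC1(C)C=C(n2ccccc2=O)c2cc(OS(=O)(=O)F)ccc2O1` is the next case and differs from compound 2 by fluorosulfonyl in place of phenylcarbamoyl on an oxygen on an aromatic ring. Among the measured compounds shown here, no pair of measured compounds separated by a single change is available, so the step has no direct precedent. The expected step, a number 0.50 log units higher from compound 2 to compound 3 (beyond the scatter), is small and upward, near the edge of the scatter. For compound 3 the expected value is 5.8, within 5 to 6.8.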

Compound 3, logarithm of the reciprocal of the active concentration, log(1/C): 7.95
Estimate against measurement, compound 3: 2.15 log units below, and the stated range ends below it.
By their numbers in this assay, from the lowest: compound 2; then compound 1; then compound 3.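

In this assay the group on the oxygen on an aromatic ring strongly shapes the read-out, with a number 2.65 log units higher from compound 2 to compound 3 (beyond the scatter) when fluorosulfonyl, with fewer heavy atoms and no ring, replaces phenylcarbamoyl. Compound 3 also passes the pyrrole-bearing compound 1, as (fluorosulfonyl)oxy in place of 2,5-dimethyl-1H-pyrrol-1-yl on an aromatic carbon gives a number 0.68 log units higher from compound 1 to compound 3 (beyond the scatter) and shows that this position does not need an aromatic ring to reach the top of the set. No measurement on hand accounts for either step.

As far as these compounds go, whether the rise belongs to fluorosulfonyl itself or to the loss of phenylcarbamoyl remains open. A methanesulfonyl or acetyl group on the same oxygen would help separate the two.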